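The source may report more compounds than this note shows. Statements on the series, on what has been measured and on what is new or still open speak of the compounds shown alone.

In a functional assay on U-251 cells (Homo sapiens) for antiproliferative activity, read by MTT assay, with a stated time of 48 h (on this read-out lower numbers stand for stronger inhibition and higher numbers for weaker inhibition), compound 1 (`COc1ccc(-c2nc3cccc(-c4cc(OC)c(OC)c(OC)c4)c3o2)cc1F`) gives 1700 nM, while compound 2 (`COc1cc(-c2cccc3nc(-c4cccc(Br)c4)oc23)cc(OC)c1OC`) gives 6800 nM, the higher of the two numbers. Compound 3 (`COc1cc(-c2cccc3nc(-c4ccc(Cl)cc4)oc23)cc(OC)c1OC`) carries 4-chlorophenyl in place of 3-bromophenyl on the same aromatic carbon, next to the ring nitrogen and next to the ring oxygen: 4-chlorophenyl in place of 3-bromophenyl on an aromatic carbon. Among the measured compounds shown here, only one measured step touches this place, a 4.0-fold higher number from compound 1 to compound 2 (0.60 log units; beyond the scatter), and it introduced the 3-bromophenyl group. A smaller step than that one is therefore expected in this assay, leaning towards a lower number and possibly within the scatter. The expected change is a 1.5-fold lower number from compound 2 to compound 3 (0.18 log units; within the scatter). The estimate for compound 3 is 4500 nM, with an expected range from 1700 nM to 12000 nM.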

Compound 3, half-maximal inhibitory concentration: 1600 nM
Compound 3: middle estimate off by 2.8-fold (0.45 log units), on the high side; measured number outside the range, below it.
By their numbers in this assay, from the lowest: compounds 3 and 1 (each within the scatter of the next); then compound 2.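

In this assay, the aryl group on this aromatic carbon can recover what 3-bromophenyl lost: 4-chlorophenyl in place of 3-bromophenyl gives a 4.3-fold lower number from compound 2 to compound 3 (0.63 log units; beyond the scatter). Against the methoxy-bearing group, 4-chlorophenyl gives a 1.1-fold lower number from compound 1 to compound 3 (0.03 log units; within the scatter), so a phenyl with a single chlorine and no methoxy matches 3-fluoro-4-methoxyphenyl within the scatter. No measurement shown accounts for the gap between the two halogenated phenyl groups. 3-bromophenyl and 4-chlorophenyl differ in both the halogen and its place on the phenyl, and the compounds shown do not separate the two. On these data alone, how an aminophenyl or a carboxylic acid on the phenyl would read at this place remains open.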